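A few compounds are considered here, and "the series" means these few. Any claim that something is new, unique, unknown or untested is made for them only; others in the source may bear on it.

Three compounds share a tetrabrominated two-ring core and differ only in what sits on the ring nitrogen and on the carbon between the two ring nitrogens. Compound 1 `Cc1nc2c(Br)c(Br)c(Br)c(Br)c2n1CC#N` carries a cyano on a saturated chain carbon bound to an aromatic nitrogen, and in a functional assay on CCRF-CEM cells (Homo sapiens) for cytotoxicity, read by MTT assay, with a stated time of 24 h, tested at 20 uM (on this read-out higher numbers stand for a weaker effect at the one concentration tested and lower numbers for a stronger effect), compound 1 gives 14%. Going by the values given here, compound 2 `Cc1nc2c(Br)c(Br)c(Br)c(Br)c2n1CCCCC#N` carries 3-cyanopropyl instead, and in this assay compound 2 gives 61%; the one measured step, a number 47 percentage points higher from compound 1 to compound 2 (beyond the scatter), shows how strongly the chain length alone can shift the read-out. Compound 3 `N#CCCn1cnc2c(Br)c(Br)c(Br)c(Br)c21` has a 2-cyanoethyl group and no methyl on the core, and in this assay compound 3 gives 44%, which places it second highest of the three, below compound 2 and above compound 1, with both gaps beyond the scatter.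

Compound 4 `Cc1nc2c(Br)c(Br)c(Br)c(Br)c2n1CCC#N` is compound 3 with one change: methyl in place of hydrogen on an aromatic carbon. The place is on an aromatic carbon of the five-membered ring with two nitrogens, between the two ring nitrogen atoms. Among the compounds with values here, none of the measured steps isolates this methyl, since compound 1 and compound 2 both already carry it and differ from compound 3 in the chain as well. Within the data shown here, with no step bearing on it, the expected step of a number 2 percentage points lower from compound 3 to compound 4 (within the scatter) is none beyond the scatter. Compound 4 is therefore estimated at 42%, within 22% to 62%.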

Compound 4, a percentage reported as activity, at one concentration (the size of the read-out at that concentration, not a potency): 51%
Compound 4: the middle estimate sits 9 percentage points below what was measured; measured number inside the range.
By their numbers in this assay, from the lowest: compound 1; then compounds 3, 4 and 2 (each within the scatter of the next, the first and the last beyond it).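

In this assay, going by these compounds alone, the methyl on this aromatic carbon, between two ring nitrogen atoms, now stands alone as the only change, and the result is a number 7 percentage points higher from compound 3 to compound 4 (within the scatter), so on the 2-cyanoethyl chain this swap of hydrogen for methyl has no effect that can be told from scatter. With the methyl held fixed, the chain comparison also splits into two parts: there is a number 37 percentage points higher from compound 1 to compound 4 (beyond the scatter), but only a number 10 percentage points lower from compound 2 to compound 4 (within the scatter), so among compound 1, compound 4 and compound 2 the real gap lies between compound 1 and the other two and is not spread evenly along the chain. No measured evidence is available to explain the behaviour of either the methyl or the chain.

It remains open whether the methyl would matter as little on the chains of compound 1 and compound 2: the compounds shown include no partner for either with hydrogen on that carbon. Also open, from the compounds shown here alone, is how the read-out would respond to an ethyl group or an amine on that carbon, or to a carboxylic acid in place of the nitrile at the chain end.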